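Para-chloro effect on two isomeric cores

The compounds below may be only part of what the source reports. "The series", "measured", "known", "first", "only" and "open" are said of these compounds alone.

Two arrangements of the same atoms are compared here. Compound 1 `O=C(NCCCCc1ccccc1)n1c(-c2ccccc2)coc1=O` and compound 3 `O=C(NCCCCc1ccccc1)n1cc(-c2ccccc2)oc1=O` share all atoms joined differently; the difference between the two cores is not broken down here. In an assay on isolated protein for inhibition of acid ceramidase (Homo sapiens), read by LC-MS, with a stated time of 1 h (a lower number here means a stronger inhibitor, a higher number a weaker inhibitor), compound 1 gives 70 nM and compound 3 gives 90 nM, the two lying within the usual scatter of each other. Compound 2 `O=C(NCCCCc1ccccc1)n1c(-c2ccc(Cl)cc2)coc1=O` carries chloro in place of hydrogen on an aromatic carbon on the core of compound 1, and the step is a 14-fold lower number from compound 1 to compound 2 (1.15 log units; beyond the scatter). Compound 4 `O=C(NCCCCc1ccccc1)n1cc(-c2ccc(Cl)cc2)oc1=O` carries the same change, (chloro in place of hydrogen on an aromatic carbon), on the core of compound 3; it remains to be measured in this assay. Among the measured compounds shown here, because compound 1 gives 70 nM and compound 2 gives 5 nM, a step of similar size is expected for compound 4, an 11-fold lower number from compound 3 to compound 4 (1.05 log units; beyond the scatter), tempered by the single precedent. Compound 4 is thus estimated at 8 nM, within 3 nM to 25 nM.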

Compound 4, half-maximal inhibitory concentration: 83 nM
Compound 4: the middle estimate sits 10-fold (1.02 log units) below what was measured; measured number above the stated range.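

On the core of compound 3, the phenyl to 4-chlorophenyl change gives no step beyond the scatter in this assay: a 1.1-fold lower number from compound 3 to compound 4 (0.04 log units; within the scatter). The change therefore does not carry over unchanged between these two cores: the same change on two cores in this assay, a 14-fold lower number (1.15 log units; beyond the scatter) from compound 1 to compound 2 and a 1.1-fold lower number (0.04 log units; within the scatter) from compound 3 to compound 4, 13-fold (1.11 log units) apart, beyond the scatter of two such steps. This shows that the size of the step differs with the core for this one change, but with a single pair on each core it does not show why, or whether any other change would differ in the same way.

Going by these compounds, it remains open whether a bromo, fluoro or methoxy group in the same place would follow compound 2 or compound 4. Also open, on these data alone, is whether a longer chain in place of the one shared by all four compounds would alter the gap between the cores.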